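Aryl-for-aryl swap on the ring amine nitrogen

This account rests on a few compounds, and the source may have more. Where it says the series, first, only, none or still open, it means among the compounds named here.

The series shares one core. Compound 1 `Nc1scc(CN2CCN(C3CCCCCC3)CC2)c1C(=O)c1ccc(Cl)cc1` carries a cycloheptyl on the ring amine nitrogen, compound 2 `Nc1scc(CN2CCN(c3cc(F)cc(F)c3)CC2)c1C(=O)c1ccc(Cl)cc1` a 3,5-difluorophenyl there. Among the measured compounds shown here, in a functional assay on CHO cells with adenosine receptor A1 (Homo sapiens) as the target, read by cAMP accumulation and immunoassay, with a stated time of 6 min, tested at 0.1 uM (on this read-out higher numbers stand for a weaker effect at the one concentration tested and lower numbers for a stronger effect), compound 1 gives 13% and compound 2 gives -5%; the one measured step is a number 18 percentage points lower from compound 1 to compound 2 (beyond the scatter). Compound 2 thus stands lowest of the two numbers, with compound 1 as its nearest point. Compound 3 `Nc1scc(CN2CCN(c3ccccc3Cl)CC2)c1C(=O)c1ccc(Cl)cc1` differs from compound 2 by 2-chlorophenyl in place of 3,5-difluorophenyl on an amine nitrogen in a ring. For the measured compounds named here, no measured step compares one aryl group with another on that nitrogen; the only step, from compound 1 to compound 2, exchanges a cycloheptyl for an aryl and so does not bear directly on this change. For compound 3 the step expected, a number 5 percentage points higher from compound 2 to compound 3 (within the scatter), is none beyond the scatter. In this assay compound 3 is therefore estimated at 0%, with a range from -15% to 15%.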

Compound 3, a percentage reported as activity, at one concentration (the size of the read-out at that concentration, not a potency): 2%
The estimate for compound 3 lay 2 percentage points below the measured number; measured number inside the range.
By their numbers in this assay, from the lowest: compounds 2 and 3 (each within the scatter of the next); then compound 1.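

Among the compounds shown here, the first aryl-for-aryl comparison on the ring amine nitrogen in this assay is a number 7 percentage points higher from compound 2 to compound 3 (within the scatter) so 2-chlorophenyl and 3,5-difluorophenyl are not told apart at this position. The step away from cycloheptyl now holds for a second aryl group, with a number 11 percentage points lower from compound 1 to compound 3 (beyond the scatter) so both aryl groups give lower numbers than cycloheptyl, and no compound shown goes against this. No measurement at hand explains these numbers.

Still open, going by these compounds, is whether an unsubstituted phenyl, a methoxyphenyl or a pyridyl on this nitrogen would read like compound 2 and compound 3, and whether a smaller ring such as cyclopentyl would read like compound 1. A read-out at one concentration also leaves open whether compound 2 and compound 3 match in potency.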